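The compounds below may be only part of what the source reports. "The series", "measured", "known", "first", "only" and "open" are said of these compounds alone.

Measured so far in a physicochemical assay for inhibition, read by spectrophotometry, with a stated time of 24 h, tested at 2.5 mM; on this read-out lower numbers stand for less inhibition and higher numbers for more inhibition at the one concentration tested (going by the name of the read-out):
Compound 1, `O=C(CCN1CCN(c2ccnc3cc(Cl)ccc23)CC1)N/N=C/c1c[nH]c2ccccc12`, gives 43.3%.
Compound 2, `COc1cc(/C=N/NC(=O)CCN2CCN(c3ccnc4cc(Cl)ccc34)CC2)ccc1OC(C)C`, gives 15.7%.
Compound 3, `NNC(=O)CCN1CCN(c2ccnc3cc(Cl)ccc23)CC1`, gives 21.7%.

Compound 3 stands second highest of the three numbers in this assay; its nearest neighbour is compound 2, whose value lies within the scatter of that of compound 3, while compound 1 sits beyond the scatter above both.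

Compound 4, `CN(C)c1ccc(/C=N/NC(=O)CCN2CCN(c3ccnc4cc(Cl)ccc34)CC2)cc1`, carries a group of 11 heavy atoms (9 carbon, 2 nitrogen; one six-membered aromatic ring of carbon only) in place of one nitrogen atom, on an amide-type nitrogen. Going by the values given here, two measured steps bear on this. The reverse of the same kind of change, a number 21.6 percentage points lower from compound 1 to compound 3 (beyond the scatter), shows that a hydrazone built on the indole gains over the bare hydrazide. Yet a number 27.6 percentage points lower from compound 1 to compound 2 (beyond the scatter) shows that a substituted phenyl on the same carbon loses most of that gain, and compound 2 ends within the scatter of compound 3. The group entering in compound 4 is a substituted phenyl rather than an indole, so compound 4 is expected to sit nearer compound 2 than compound 1, with a step of a number 4.3 percentage points higher from compound 3 to compound 4 (within the scatter) in this assay, likely within the scatter. The estimate for compound 4 in this assay is therefore 26%, ranging from 12% to 42%.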

Compound 4, a percentage reported as inhibition, at one concentration (the size of the read-out at that concentration, not a potency): 94.2%
Estimate against measurement, compound 4: 68.2 percentage points below, outside the stated range (above it).
By their numbers in this assay, from the lowest: compounds 2 and 3 (each within the scatter of the next); then compound 1; then compound 4.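

At the carbon with a double bond to nitrogen, the group carried can raise the read-out in this assay well past the indole, not only fall short of it: 4-(dimethylamino)phenyl in place of 1H-indol-3-yl gives a number 50.9 percentage points higher from compound 1 to compound 4 (beyond the scatter). Substituted phenyls at this carbon do not behave alike: 4-(dimethylamino)phenyl in place of 4-isopropoxy-3-methoxyphenyl gives a number 78.5 percentage points higher from compound 2 to compound 4 (beyond the scatter). The group of 11 heavy atoms in place of the amino group on the amide-type nitrogen gives a number 72.5 percentage points higher from compound 3 to compound 4 (beyond the scatter), so the outcome depends on which group enters, and compound 2 goes against any general gain from the addition.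

Nothing available explains these differences. Whether the dimethylamino group itself accounts for the result stays open; 4-aminophenyl or unsubstituted phenyl on the same carbon would bear on this.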